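The source may hold more compounds than are shown below. What is called first, only, known or untested is meant among the compounds shown, and "the series" means these compounds.

Measured so far in a functional assay on A-375 cells (Homo sapiens) for antiproliferative activity, read by MTT assay, with a stated time of 24 h, tested at 3.7 ug/mL; a higher number here means a stronger effect of the compound at the concentration tested, a lower number a weaker effect:
- compound 1, `Cc1ccc2nc(C(=O)Nc3c(F)cc(-c4cccc(F)c4)cc3F)c(C)c(O)c2c1`, gives 16.2%
- compound 2, `Cc1c(C(=O)Nc2c(F)cc(-c3cccc(F)c3)cc2F)nc2ccc(C(F)(F)F)cc2c1O`, gives 34.3%

Compound 1 stands lowest of the two numbers in this assay; its nearest neighbour is compound 2, reached by a number 18.1 percentage points higher from compound 1 to compound 2 (beyond the scatter), a trifluoromethyl in place of methyl on an aromatic carbon.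

The next compound, compound 3, `Cc1ccc2nc(C(=O)Nc3c(F)cc(-c4cccc(F)c4)cc3F)c(C)c(C(=O)O)c2c1`, differs from compound 1 at one place: carboxy in place of hydroxy on an aromatic carbon. The change is a carboxy in place of hydroxy on an aromatic carbon of the shared core.

Among the compounds with values here, no measured step bears on this change. Within the data shown here, the only step in hand, a number 18.1 percentage points higher from compound 1 to compound 2 (beyond the scatter), concerns a trifluoromethyl in place of methyl elsewhere on the core and says nothing about the hydroxy position. The two values of compound 1 and compound 2 show only that the series can move by a modest amount within this assay.

Among the measured compounds shown here, with no relevant step, no change beyond the scatter is expected for compound 3, so the estimated step is a number 0.8 percentage points higher from compound 1 to compound 3 (within the scatter), with a wide range to either side. Compound 3 is therefore expected to give 17% in this assay, estimated between 3% and 40%.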

Compound 3, a percentage reported as inhibition, at one concentration (the size of the read-out at that concentration, not a potency): 9.25%
The estimate for compound 3 lay 7.8 percentage points above the measured number; the range from low to high includes it.
By their numbers in this assay, from the lowest: compounds 3 and 1 (each within the scatter of the next); then compound 2.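

In this assay, the step at this position is a number 7 percentage points lower from compound 1 to compound 3 (within the scatter) and leaves compound 3 and compound 1 indistinguishable. Within the data shown here, this is the first direct reading at the aromatic carbon opposite the ring nitrogen, ortho to a methyl group, where the earlier compounds both carry hydroxy. At this single tested concentration, the exchange of hydroxy for carboxy, which brings an added carbon and a double bond outside aromatic rings, therefore gives no separable change in the read-out, and no measurement bearing on the reason for this result is available.

Because only hydroxy and carboxy are shown here, it remains open whether an amine, a methoxy group or a methyl ester at the same carbon would also leave the read-out within the scatter of compound 1, or would move it beyond that scatter. From the compounds shown here alone, it is also open whether the trifluoromethyl in place of methyl seen in a number 18.1 percentage points higher from compound 1 to compound 2 (beyond the scatter) would carry over to a compound holding carboxy at this position, and a single-concentration read-out in this assay cannot settle how potency compares across these compounds.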